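From 4-Nitrophenyl to 4-Chlorophenyl on the Shared Core

The compounds below may be only part of what the source reports. "The series", "measured", "known", "first", "only" and "open" are said of these compounds alone.

In a functional assay on K562 cells (Homo sapiens) for cytotoxicity, read by MTT assay, with a stated time of 72 h (on this read-out lower numbers stand for stronger inhibition and higher numbers for weaker inhibition), compound 1 `C=C1C(=O)[C@@]23C(=O)OC[C@]4(C(=O)CCC(C)(C)[C@H]4C=O)[C@@H]2CC[C@@H]1[C@H]3O`, which has hydrogen on an oxygen on a saturated carbon, gives 2180 nM. With (4-methylphenyl)carbonyl on that oxygen, compound 2 `C=C1C(=O)[C@@]23C(=O)OC[C@]4(C(=O)CCC(C)(C)[C@H]4C=O)[C@@H]2CC[C@@H]1[C@H]3OC(=O)c1ccc(C)cc1` gives 1270 nM. With (4-nitrophenyl)carbonyl there, compound 3 `C=C1C(=O)[C@@]23C(=O)OC[C@]4(C(=O)CCC(C)(C)[C@H]4C=O)[C@@H]2CC[C@@H]1[C@H]3OC(=O)c1ccc([N+](=O)[O-])cc1` gives 1330 nM, which lies within the scatter of both other values.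

Compound 4 `C=C1C(=O)[C@@]23C(=O)OC[C@]4(C(=O)CCC(C)(C)[C@H]4C=O)[C@@H]2CC[C@@H]1[C@H]3OC(=O)c1ccc(Cl)cc1` differs from compound 3 by one change: chloro in place of nitro on an aromatic carbon. This places chloro in place of nitro on an aromatic carbon, para to a large group. The closest evidence is a 1.0-fold higher number from compound 2 to compound 3 (0.02 log units; within the scatter), which exchanged methyl for nitro on the same aromatic carbon and stayed within the scatter. The other two steps, a 1.7-fold lower number from compound 1 to compound 2 (0.23 log units; within the scatter) and a 1.6-fold lower number from compound 1 to compound 3 (0.21 log units; within the scatter), also stayed within it. No step beyond the scatter is therefore expected in this assay. The expected change is a 1.1-fold lower number from compound 3 to compound 4 (0.03 log units; within the scatter). For compound 4 the estimated value is 1250 nM, with an expected range of 650 nM to 2400 nM.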

Compound 4, half-maximal inhibitory concentration: 1380 nM
Estimate against measurement, compound 4: 1.1-fold (0.04 log units) below, within the range that was stated.
By their numbers in this assay, from the lowest: compounds 2, 3, 4 and 1 (each within the scatter of the next).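

In this assay chloro in place of nitro gives a 1.0-fold higher number from compound 3 to compound 4 (0.02 log units; within the scatter) and chloro in place of methyl gives a 1.1-fold higher number from compound 2 to compound 4 (0.04 log units; within the scatter) on this aromatic carbon, so methyl, nitro and chloro cannot be told apart here. Even the exchange of nitro, which carries hydrogen-bond acceptors, for chloro, which carries none, stays within the scatter. Placing (4-chlorophenyl)carbonyl on the oxygen gives a 1.6-fold lower number from compound 1 to compound 4 (0.20 log units; within the scatter) and so, like the other two aromatic groups, does not take the number beyond the scatter of the compound with hydrogen there.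

Nothing available explains why these groups give such close numbers. Going by these compounds, whether an amine or a carboxylic acid on this aromatic carbon, or a longer chain in place of the aromatic ring on the oxygen, would give a step beyond the scatter remains open.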